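From a propyl to a 3-methoxyphenyl group

The compounds below may be only part of what the source reports. "The series", "measured", "known", "first", "only" and "open" are said of these compounds alone.

Measured in a functional assay on MDA-MB-231 cells (Homo sapiens) for antiproliferative activity, read by MTT assay, with a stated time of 72 h; on this read-out higher numbers stand for weaker inhibition and lower numbers for stronger inhibition:
- Compound 1 `CCCn1ccnc1-c1cc(OC)c(OC)c(OC)c1` gives > 100000 nM, which is a limit
- Compound 2 `COc1cc(-c2nccn2-c2ccc3sccc3c2)cc(OC)c1OC` gives 16800 nM

Compound 1 has no exact value and stands only at a limit: the limit of > 100000 nM in this assay, at which 1 of the 2 values shown sits. Compound 3 `COc1cccc(-n2ccnc2-c2cc(OC)c(OC)c(OC)c2)c1` carries 3-methoxyphenyl in place of propyl on an aromatic nitrogen. Among the compounds with values here, no measured step shows this exchange. Compound 2, with an aromatic group on that nitrogen, gives 16800 nM, and this single value is the ground for expecting stronger inhibition. The expected change in this assay is an at least 6.6-fold lower number from compound 1 to compound 3 (0.82 log units; beyond the scatter). Compound 3 is estimated at 15000 nM, with an expected range of 2000 nM to 100000 nM.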

Compound 3, half-maximal inhibitory concentration: 18300 nM
Beside the measured number, compound 3's estimate is 1.2-fold (0.09 log units) below it; the measured number falls inside the stated range.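

In this assay, within the data shown here, 3-methoxyphenyl in place of propyl on the aromatic nitrogen gives an at least 5.4-fold lower number from compound 1 to compound 3 (0.73 log units; beyond the scatter), the first measured step at this position. With an aromatic group on that nitrogen, compound 2 gives 16800 nM and compound 3 gives 18300 nM, two values within the usual scatter of each other. Compound 1 stands at a limit, so the step to compound 3 is a bound and not an exact size: the limit of > 100000 nM in this assay, at which 1 of the 3 values shown sits.

The compounds shown leave open whether the methoxy group matters, since a plain phenyl or a hydroxyphenyl group is not among them. They also leave open how a longer chain or an amine would behave on that nitrogen.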